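The compounds below may be only part of what the source reports. "The series", "measured", "known", "first", "only" and "open" are said of these compounds alone.

Measured in a functional assay (trachea) with Cavia porcellus as the target; a higher number here means a weaker inhibitor, a lower number a stronger inhibitor:
- compound 1 `O=c1c2ccccc2c(-c2cccnc2)nn1Cc1cccc(Cl)c1`: 4170 nM
- compound 2 `CCOC(=O)Cn1nc(-c2cccnc2)c2ccccc2c1=O`: 43700 nM

Of these two numbers in this assay, compound 2 has the higher, at 43700 nM, which makes it the weaker inhibitor of the pair. The next compound, compound 3 `CCOC(=O)CCCn1nc(-c2cccnc2)c2ccccc2c1=O`, keeps the shared core and changes only the side chain: 2-(ethoxycarbonyl)ethyl in place of ethoxycarbonyl on a saturated chain carbon bound to an aromatic nitrogen. In words, this is 2-(ethoxycarbonyl)ethyl in place of ethoxycarbonyl on a saturated chain carbon bound to an aromatic nitrogen.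

Within the data shown here, only one measured step bears on this change. It falls at the same place, and a 10-fold higher number from compound 1 to compound 2 (1.02 log units; beyond the scatter) is large and beyond the scatter. That step shows that the number responds to what is attached there, but it exchanges 3-chlorophenyl for ethoxycarbonyl. Among the measured compounds shown here, it therefore says nothing direct about going from (ethoxycarbonyl)methyl to 3-(ethoxycarbonyl)propyl, and no measured pair tests that change. A much smaller move towards a lower number is therefore expected, and the estimated change is a 2.2-fold lower number from compound 2 to compound 3 (0.34 log units; beyond the scatter). For compound 3 the expected value is 20000 nM, with an estimated range of 5000 nM to 60000 nM.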

Compound 3, half-maximal inhibitory concentration: 10000 nM
Compound 3: the middle estimate sits 2.0-fold (0.30 log units) above what was measured; measured number inside the range.
By their numbers in this assay, from the lowest: compound 1; then compound 3; then compound 2.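

In this assay, the side chain keeps its ethyl ester and only moves it further out, from (ethoxycarbonyl)methyl to 3-(ethoxycarbonyl)propyl, and this alone gives a 4.4-fold lower number from compound 2 to compound 3 (0.64 log units; beyond the scatter). Among these compounds, the earlier step showed only that the number responds when one group is exchanged for a quite different one, whereas this step shows that it also responds to the length of the chain carrying the same ester. The longer ester still does not close the gap to the 3-chlorophenyl compound, with a 2.4-fold higher number from compound 1 to compound 3 (0.38 log units; beyond the scatter), so compound 1 remains the strongest inhibitor of the three, and nothing available explains why the longer chain lowers the number or why the gap remains.

From the compounds shown here alone, with only these two ester chains in hand, it remains open whether a still longer chain would lower the number further or reverse the trend. Going by these compounds, it is also open whether the ester itself matters, as a carboxylic acid or an amine at the end of the same chain would show, and whether 3-chlorophenyl on a longer chain would respond as the ester did.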